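Cyanoguanidine amides: methoxyphenyl chain variants

The source may report more compounds than this note shows. Statements on the series, on what has been measured and on what is new or still open speak of the compounds shown alone.

Measured:
compound 1 `Cc1ccccc1N/C(=N\C#N)NC(NC(=O)CCCc1ccccc1)C(C)(C)C` — 79.4 nM
compound 2 `COc1ccc(CCC(=O)NC(N/C(=N/C#N)Nc2ccccc2C)C(C)(C)C)cc1OC` — 200 nM

In a functional assay on HEK293 cells for antagonist activity at P2X purinoceptor 7 (Homo sapiens), read by FLIPR and calcium flux (on this read-out lower numbers stand for stronger inhibition and higher numbers for weaker inhibition), compound 1 gives 79.4 nM and compound 2 gives 200 nM. Compound 2 holds the highest number of the two; the step of a 2.5-fold higher number from compound 1 to compound 2 (0.40 log units; beyond the scatter) is modest but beyond the scatter.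

Compound 3 `COc1ccc(CCCC(=O)NC(N/C(=N/C#N)Nc2ccccc2C)C(C)(C)C)cc1` is not yet measured. It differs from compound 2 by 4-methoxybenzyl in place of 3,4-dimethoxyphenyl on a saturated chain carbon, two bonds along the chain from a carbonyl carbon. Seen from compound 1, compound 3 keeps the chain of compound 1 and carries one methoxy group on the ring instead of the two of compound 2.

Among the compounds with values here, the only step bearing on this is a 2.5-fold higher number from compound 1 to compound 2 (0.40 log units; beyond the scatter), which combined a shorter chain with two methoxy groups. Compound 3 undoes part of that change. The expectation is therefore a number for compound 3 somewhat lower than that of compound 2, with the step of a 1.8-fold lower number from compound 2 to compound 3 (0.26 log units; within the scatter) estimated to lie near the edge of the scatter. Compound 3 is estimated at 110 nM in this assay, with a range of 45 nM to 270 nM.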

Compound 3, half-maximal inhibitory concentration: 79.4 nM
Beside the measured number, compound 3's estimate is 1.4-fold (0.14 log units) above it, and the stated range covers the measured number.
By their numbers in this assay, from the lowest: compounds 1 and 3 (each within the scatter of the next); then compound 2.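

In this assay, 4-methoxybenzyl in place of 3,4-dimethoxyphenyl on a saturated chain carbon, two bonds along the chain from a carbonyl carbon, gives a 2.5-fold lower number from compound 2 to compound 3 (0.40 log units; beyond the scatter), which matches the size of a 2.5-fold higher number from compound 1 to compound 2 (0.40 log units; beyond the scatter) in the opposite direction. The new information is that methoxy in place of hydrogen on an aromatic carbon gives no change at the digits printed from compound 1 to compound 3 (within the scatter), so on the chain of compound 1 this single methoxy leaves the read-out within the scatter, and the higher number of compound 2 does not appear with it. No measurement here accounts for these steps or explains how the chain and the ring substituents contribute to them.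

The change from compound 2 to compound 3 alters the chain and the methoxy pattern together, so the compounds shown cannot assign the step to either one, and 3,4-dimethoxyphenyl on the chain of compound 3 or 4-methoxyphenyl on the chain of compound 2 would be needed to separate them. Also open, going by these compounds, is how a longer chain, or a chloro group, hydroxy group or amine on the ring in place of methoxy, would read in this assay.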